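This account rests on a few compounds, and the source may have more. Where it says the series, first, only, none or still open, it means among the compounds named here.

In an ADME assay on microsomes from liver (Canis lupus familiaris) for metabolic stability, read by LC-MS, using NADPH, with a stated time of 10 min, tested at 0.1 uM (a lower number here means slower removal, a higher number faster removal of the compound), compound 1 (`O=C(NCCCCc1ccccc1)c1cccc(C2SCC(=O)N2c2cccc(F)c2)c1`) gives 837 mL.min-1.g-1 and compound 2 (`O=C(NCCCCc1ccccc1)c1cccc(C2SCC(=O)N2c2ccccc2F)c1`) gives 815 mL.min-1.g-1 so compound 2 stands level with compound 1 within the scatter. Compound 3 (`O=C(NCCCCc1ccccc1)c1cccc(C2SCC(=O)N2c2ccc(C3CC3)cc2)c1`) carries 4-cyclopropylphenyl in place of 2-fluorophenyl on an amide-type nitrogen in a ring. Among the measured compounds shown here, the one measured step at this place is a 1.0-fold lower number from compound 1 to compound 2 (0.01 log units; within the scatter) and it only exchanges 3-fluorophenyl for 2-fluorophenyl, so it offers limited guidance. For the measured compounds named here, no measured compound holds a cyclopropyl group. No step beyond the scatter is expected in this assay (a 1.1-fold higher number from compound 2 to compound 3 (0.04 log units; within the scatter)). The estimated value for compound 3 is 900 mL.min-1.g-1 (range 500 mL.min-1.g-1 to 1600 mL.min-1.g-1).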

Compound 3, intrinsic clearance in microsomes: 1080 mL.min-1.g-1
Compound 3: the middle estimate sits 1.2-fold (0.08 log units) below what was measured; measured number inside the range.
By their numbers in this assay, from the lowest: compounds 2, 1 and 3 (each within the scatter of the next).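

In this assay, 4-cyclopropylphenyl in place of 2-fluorophenyl gives a 1.3-fold higher number from compound 2 to compound 3 (0.12 log units; within the scatter), and in place of 3-fluorophenyl it gives a 1.3-fold higher number from compound 1 to compound 3 (0.11 log units; within the scatter). This position on the amide-type nitrogen therefore takes an added three-membered carbon ring and loses fluorine without a step beyond the scatter, whereas the earlier pair covered only a move of fluorine. Nothing at hand bears on the cause of these results. Open, from the compounds shown here alone, is whether an amine or a carboxylic acid on this phenyl would give a step beyond the scatter, and whether a change elsewhere on the shared core would.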